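Swapping methoxy for fluoro on the amide aryl ring

The source may hold more compounds than are shown below. What is called first, only, known or untested is meant among the compounds shown, and "the series" means these compounds.

Of the compounds shown here, two of the same core have been measured in a functional assay on A549 cells (Homo sapiens) for inhibition, read by MTT assay, with a stated time of 48 h; a lower number here means a stronger inhibitor, a higher number a weaker inhibitor. Compound 1 `COc1ccc2c(=O)c(/C=C/C(=O)Nc3cc(C)ccc3C)coc2c1` gives 15500 nM in this assay. Compound 2 `COc1ccc(NC(=O)/C=C/c2coc3cc(OC)ccc3c2=O)cc1` gives 23000 nM in this assay. Going by the values given here, the only step between them, a 1.5-fold higher number from compound 1 to compound 2 (0.17 log units; within the scatter), changes the whole aryl group on the amide nitrogen, and it is within the scatter. Compound 2 therefore holds the higher of the two numbers, but the gap to compound 1 is one that repeated measurements could produce on their own.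

Compound 3 `COc1ccc2c(=O)c(/C=C/C(=O)Nc3ccc(F)cc3)coc2c1` differs from compound 2 by fluoro in place of methoxy on an aromatic carbon. Among the compounds with values here, the one measured step that bears on this change, from 2,5-dimethylphenyl to 4-methoxyphenyl, was within the scatter, so a change on the same aryl ring that leaves the rest of the molecule untouched gives no reason to expect a step beyond the scatter in this assay, in either direction. The expected step for compound 3 is a 1.2-fold lower number from compound 2 to compound 3 (0.06 log units; within the scatter). Compound 3 is thus estimated at 20000 nM in this assay, with a range from 8000 nM to 50000 nM.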

Compound 3, half-maximal inhibitory concentration: 26800 nM
Compound 3: middle estimate off by 1.3-fold (0.13 log units), on the low side, within the range that was stated.
By their numbers in this assay, from the lowest: compounds 1, 2 and 3 (each within the scatter of the next).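

In this assay the change from 4-methoxyphenyl to 4-fluorophenyl, made on an aromatic carbon para to a large group, gives a 1.2-fold higher number from compound 2 to compound 3 (0.07 log units; within the scatter) and so does not separate these two compounds. Set against the 2,5-dimethylphenyl group, the 4-fluorophenyl group gives a 1.7-fold higher number from compound 1 to compound 3 (0.24 log units; within the scatter) which means that all three aryl groups on the amide nitrogen now lie within the scatter of one another, a wider comparison than the single step available before. The methoxy group counts as one hydrogen-bond acceptor and the fluoro group as none, so for this one pair, losing that acceptor and one heavy atom at this position produces no difference that can be read in this assay.

The compounds shown leave open whether an amine, a carboxylic acid or a longer chain such as butoxy at this position would give a step beyond the scatter, since all three aryl groups here carry only methyl, methoxy or fluoro. No measured evidence is available to explain why these aryl groups read alike.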